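The source may report more compounds than this note shows. Statements on the series, on what has been measured and on what is new or still open speak of the compounds shown alone.

Measured in a functional assay on A549 cells (Homo sapiens) for antiproliferative activity, read by MTT assay, with a stated time of 72 h; on this read-out higher numbers stand for weaker inhibition and lower numbers for stronger inhibition:

- compound 1 `COc1cc2ncnc(N3CCc4ccccc43)c2cc1NC(=O)/C=C/C(C)C` gives 6410 nM
- compound 2 `C=CC(=O)Nc1cc2c(N3CCc4ccccc43)ncnc2cc1O[C@@H]1CCOC1` gives 9320 nM
- compound 3 `CC(C)/C=C/C(=O)Nc1cc2c(N3CCc4ccccc43)ncnc2cc1O[C@@H]1CCOC1` gives 8520 nM

The three values sit close together. Compound 3 at 8520 nM lies within the scatter of both other compounds.

The next compound is compound 4 `O=C(/C=C/CN1CCCCC1)Nc1cc2c(N3CCc4ccccc43)ncnc2cc1O[C@@H]1CCOC1`, in which (piperidin-1-yl)methyl stands in place of isopropyl on a double-bonded chain carbon bound to a double-bonded chain carbon. The counted difference is (piperidin-1-yl)methyl in place of isopropyl on a double-bonded chain carbon bound to a double-bonded chain carbon.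

Two measured steps are available. The more relevant one changes the same chain: a 1.1-fold lower number from compound 2 to compound 3 (0.04 log units; within the scatter). The other, a 1.3-fold higher number from compound 1 to compound 3 (0.12 log units; within the scatter), concerns the group on oxygen, a different place, and so bears on this change only weakly. Within the data shown here, both steps stay within the scatter, but neither brings a ring or a nitrogen into the chain, and no measured compound carries piperidin-1-yl. The new group is therefore untested in this series, and the range has to stay wide on both sides.

In this assay no step beyond the scatter is expected, and the estimated step is a 1.4-fold lower number from compound 3 to compound 4 (0.15 log units; within the scatter). For compound 4 the estimated value is 6000 nM, with an expected range from 2000 nM to 13000 nM.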

Compound 4, half-maximal inhibitory concentration: 4660 nM
Beside the measured number, compound 4's estimate is 1.3-fold (0.11 log units) above it; low and high end bracket the measured number.
By their numbers in this assay, from the lowest: compounds 4, 1, 3 and 2 (each within the scatter of the next).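

In this assay, among these compounds, the earlier compounds carried only open carbon groups at this place, whereas compound 4 brings a six-membered non-aromatic ring with one nitrogen onto the double-bonded chain carbon. Replacing isopropyl with (piperidin-1-yl)methyl keeps the read-out within the scatter (a 1.8-fold lower number from compound 3 to compound 4 (0.26 log units; within the scatter)), and the wider comparison of 3-(piperidin-1-yl)prop-1-en-1-yl with vinyl on the carbonyl carbon also stays within it (a 2.0-fold lower number from compound 2 to compound 4 (0.30 log units; within the scatter)), so this place accepts the added ring and hydrogen-bond acceptor with no shift beyond the scatter in this assay. No supporting data are available to explain these small differences.

Still open, as far as these compounds go, is whether another amine on the same methyl carbon, such as dimethylamino or morpholin-4-yl, or a carboxylic acid in that place would give a step beyond the scatter. Also open, from the compounds shown here alone, is whether (piperidin-1-yl)methyl would read the same with methyl in place of oxolan-3-yl on the oxygen, since the chain change has been read here only with oxolan-3-yl present.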